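The source may report more compounds than this note shows. Statements on the series, on what has been measured and on what is new or still open speak of the compounds shown alone.

Compound 1 `COc1ccc(/C=C2\CCC/C(=C\c3ccc(OC)c(OC)c3)C2=O)cc1` is one of three close relatives examined in a functional assay on A549 cells (Homo sapiens) for cytotoxicity, read by MTT assay, with a stated time of 72 h; a higher number here means a weaker inhibitor, a lower number a stronger inhibitor. In this assay compound 1 reaches only the limit > 20000 nM, a cut-off of the assay rather than a number. Compound 2 `COc1ccc(/C=C2\CCC/C(=C\c3ccc(OC)c(OC)c3)C2=O)c(OC)c1` also stops at that limit in this assay, with > 20000 nM. Among the compounds with values here, compound 3 `COc1ccc(/C=C2\CCC/C(=C\c3ccc(OC)c(OC)c3)C2=O)cc1OC` is the one member that gives a readable number in this assay, namely 8500 nM. Both measured steps add a methoxy to the shared core of compound 1: a step that the two limits leave unreadable from compound 1 to compound 2 and an at least 2.3-fold lower number from compound 1 to compound 3 (0.37 log units; beyond the scatter). Compound 1 thus stands at the weak end of what is known, anchored by the limit of > 20000 nM in this assay, at which 2 of the 3 values shown sit.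

Compound 4 `COc1ccc(/C=C2\CCC/C(=C\c3ccc(O)c(O)c3)C2=O)cc1OC` differs from compound 1 by 3,4-dihydroxyphenyl in place of 4-methoxyphenyl on a double-bonded chain carbon bound to a double-bonded ring carbon. Within the data shown here, no measured step alters this group, so the measured steps bear on it only loosely, and the expectation rests on compound 1 standing at the limit > 20000 nM. For compound 4 the account expects a step of an at least 1.6-fold lower number from compound 1 to compound 4 (0.22 log units; that floor lies within the scatter) in this assay, with the sign uncertain. Compound 4 is estimated at 12000 nM, between 3000 nM and 40000 nM.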

Compound 4, half-maximal inhibitory concentration: > 20000 nM
Compound 4 ended at the assay's limit; the forecaster's own chance of this, stated with the estimate: 40%; middle value at least 1.6-fold (0.22 log units) from the limit.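

Compound 4 gives only a limit in this assay, > 20000 nM. Within the data shown here, compound 1 also stands at a limit, and no step between these two compounds can be read. The compounds shown leave open whether 3,4-dihydroxyphenyl in place of 4-methoxyphenyl changes the number at all, in either direction.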